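The source may report more compounds than this note shows. Statements on the series, on what has been measured and on what is new or still open speak of the compounds shown alone.

Three compounds sharing one core were measured in an assay on HEK293 cells for inhibition of Steryl-sulfatase (Homo sapiens), tested at 1 uM; on this read-out lower numbers stand for a weaker effect and higher numbers for a stronger effect at the one concentration tested. Compound 1 `NS(=O)(=O)Oc1ccc2c(c1)CN(C(=O)c1cccc(N(Cc3ccccc3)Cc3ccco3)c1)CC2` gives 90.5%, compound 2 `NS(=O)(=O)Oc1ccc2c(c1)CN(C(=O)c1ccc(N3CCCCC3)cc1)CC2` gives 38.3%, and compound 3 `CCN(Cc1ccncc1)c1cccc(C(=O)N2CCc3ccc(OS(N)(=O)=O)cc3C2)c1` gives 52.8%. Compound 3 therefore stands second highest of the three: compound 2 is the nearest to it, lower by an amount beyond the scatter, and compound 1 is the furthest, higher by an amount beyond the scatter. Compound 4 `CCN(Cc1cccnc1)c1cccc(C(=O)N2CCc3ccc(OS(N)(=O)=O)cc3C2)c1` holds the same atoms as compound 3, joined differently: pyridin-3-yl in place of pyridin-4-yl on a saturated chain carbon bound to a nitrogen on an aromatic ring. For the measured compounds named here, no measured pair of compounds differs only in this way, so the size of such a step is unknown from the data. One expects at most a small step from compound 3 to compound 4, a number 2.8 percentage points lower from compound 3 to compound 4 (within the scatter), not beyond the scatter in either direction. For compound 4 in this assay the estimate is 50%, within a range from 30% to 70%.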

Compound 4, a percentage reported as inhibition, at one concentration (the size of the read-out at that concentration, not a potency): 33.5%
Compound 4: middle estimate off by 16.5 percentage points, on the high side; the range from low to high includes it.
By their numbers in this assay, from the lowest: compounds 4 and 2 (each within the scatter of the next); then compound 3; then compound 1.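

In this assay, pyridin-3-yl in place of pyridin-4-yl on a saturated chain carbon bound to a nitrogen on an aromatic ring gives a number 19.3 percentage points lower from compound 3 to compound 4 (beyond the scatter), although the two groups count the same atoms, donors and acceptors. For the compounds shown here, this is the first pair differing in one place, and it shows that the read-out at this position depends on which pyridine isomer is attached. Nothing at hand accounts for the size of this step. As far as these compounds go, it remains open how pyridin-2-yl would read at this place, and whether the step would persist with propyl instead of ethyl on the same nitrogen.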